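Aryl Sulfonamide Variation on a Shared Core

This account rests on a few compounds, and the source may have more. Where it says the series, first, only, none or still open, it means among the compounds named here.

Compound 1 `CC(=O)Nc1ccc(S(=O)(=O)NC2=NCCN2C(=S)SN2CCn3c2nsc3=S)cc1` gives >= 20000 nM in a functional assay on KYSE-510 cells (Homo sapiens) for antiproliferative activity, read by crystal violet staining, with a stated time of 96 h (a lower number here means a stronger inhibitor of growth, a higher number a weaker inhibitor of growth), a limit rather than a number.
Compound 2 `O=S(=O)(NC1=NCCN1C(=S)SN1CCn2c1nsc2=S)c1ccc(Br)cc1` gives >= 20000 nM in this assay, again a limit.
Compound 3 `O=S(=O)(NC1=NCCN1C(=S)SN1CCn2c1nsc2=S)c1ccccc1Cl` gives >= 20000 nM in this assay, also a limit.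

Compound 3 therefore has no measured number of its own; it stands at the limit of >= 20000 nM in this assay, at which 3 of the 3 values shown sit, together with both other compounds. The three measured steps, a step that the two limits leave unreadable from compound 1 to compound 2, a step that the two limits leave unreadable from compound 1 to compound 3 and a step that the two limits leave unreadable from compound 2 to compound 3, are all unreadable, since the two limits hide whatever difference exists between the compounds.

Compound 4 `O=S(=O)(NC1=NCCN1C(=S)SN1CCn2c1nsc2=S)c1ccc(F)c(Cl)c1` is the compound not yet measured. It differs from compound 3 in one place: 3-chloro-4-fluorophenyl in place of 2-chlorophenyl on a sulfonyl sulfur.

Going by the values given here, none of the measured steps can give a size for this change, as each lies between two limits. What the measurements do show is that every aryl group tried so far on the sulfonyl sulfur left the compound at the limit of >= 20000 nM in this assay, at which 3 of the 3 values shown sit. On that basis compound 4 is expected to behave the same way, with a number no higher from compound 3 to compound 4 (the limit leaves the size open) estimated as no readable step in this assay. The estimate for compound 4 is 20000 nM, within a range of 8000 nM to 50000 nM, most likely reported again only as a limit.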

Compound 4, concentration for 50% growth inhibition: >= 20000 nM
Compound 4 ended at the assay's limit (the forecaster's own chance of this, stated with the estimate: 80%); the middle value lies on the limit itself.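

Compound 4 joins compound 1, compound 2 and compound 3 at a limit rather than a number, so none of the steps to compound 4 can be read: the limit of >= 20000 nM in this assay, at which 4 of the 4 values shown sit.

In this assay the compounds shown leave open how far these aryl groups on the sulfonyl sulfur differ, and whether any aryl group there gives a measurable number on the shared core.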